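This account rests on a few compounds, and the source may have more. Where it says the series, first, only, none or still open, it means among the compounds named here.

Three compounds share one core. Compound 1 `Nc1cc(N)c2nc(-c3ccccc3)c(Oc3ccc(Cl)c(Cl)c3)nc2c1` carries a 3,4-dichlorophenoxy group, and in a functional assay on TK-10 cells (Homo sapiens) for inhibition, read by sulforhodamine B assay, with a stated time of 48 h (on this read-out higher numbers stand for weaker inhibition of growth and lower numbers for stronger inhibition of growth), compound 1 gives 24500 nM. Compound 2 `Nc1cc(N)c2nc(-c3ccccc3)c(Sc3ccc(F)cc3)nc2c1` carries a (4-fluorophenyl)sulfanyl group in the same position. In this assay compound 2 reaches only a limit of the assay, < 100000 nM, and no number. The measured step that the limit leaves unreadable from compound 1 to compound 2 therefore cannot be read in size, as the limit of < 100000 nM in this assay, at which 1 of the 2 values shown sits, shows; compound 2 stands on a limit alone, not on a value.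

Compound 3 `Nc1cc(N)c2nc(-c3ccccc3)c(Oc3ccc(F)cc3)nc2c1` has not yet been measured in this assay. Its difference from compound 2 is 4-fluorophenoxy in place of (4-fluorophenyl)sulfanyl on an aromatic carbon. Within the data shown here, no measured step in this set changes a sulfanyl linkage into an ether linkage with the same ring, so nothing here speaks directly to the size or direction of the step to compound 3. Among the measured compounds shown here, the only number in the set is that of compound 1, which carries an ether linkage too. On that footing compound 3 is expected to give about 30000 nM in this assay, within a range from 8000 nM to 100000 nM, which means an estimated step that the limit leaves unreadable from compound 2 to compound 3 that stays uncertain because compound 2 sits on the limit (the limit of < 100000 nM in this assay, at which 1 of the 2 values shown sits).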

Compound 3, concentration for 50% growth inhibition: 16600 nM
Beside the measured number, compound 3's estimate is 1.8-fold (0.26 log units) above it; measured number inside the range.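

In this assay, the exchange of 3,4-dichlorophenyl for 4-fluorophenyl on the oxygen gives a 1.5-fold lower number from compound 1 to compound 3 (0.17 log units; within the scatter), so compound 1 and compound 3 cannot be told apart on this read-out, and at this position the two halogenated rings on an ether linkage give the same result within the scatter. The new comparison of the sulfanyl and ether linkages with the same 4-fluorophenyl ring, like the earlier step between the two other compounds, cannot be read in size, so compound 3 adds no measure of what the linkage atom contributes. Compound 2 stands on a limit of the assay and not on a number: the limit of < 100000 nM in this assay, at which 1 of the 3 values shown sits.

The compounds shown leave open whether a linkage through an amine nitrogen or a methylene group at this aromatic carbon would give a number apart from those of the two ether compounds. They also leave open whether a phenyl ring with no halogen, or one carrying a methoxy group or a carboxylic acid, would behave differently on the same oxygen.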